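From carbamoyl to 1H-tetrazol-5-yl at a tolerance limit

The source may report more compounds than this note shows. Statements on the series, on what has been measured and on what is new or still open speak of the compounds shown alone.

Compound 1 `CC(C)(C)c1ccc(C(=O)Nc2cc(Cl)c(Br)nc2C(=O)O)cc1`: > 50000 nM
Compound 2 `CC(C)(C)c1ccc(C(=O)Nc2cc(Cl)cnc2C(N)=O)cc1`: > 50000 nM

In an ADME assay on HFF cells (Homo sapiens) for cytotoxicity, with a stated time of 72 h (a higher number here means that more compound is tolerated, a lower number that less compound is tolerated), compound 2 gives > 50000 nM, which is a limit of the assay and not a number. Both measured compounds stand at the limit of > 50000 nM in this assay, at which 2 of the 2 values shown sit. Compound 3 `CC(C)(C)c1ccc(C(=O)Nc2cc(Cl)cnc2-c2nnn[nH]2)cc1` differs from compound 2 by 1H-tetrazol-5-yl in place of carbamoyl on an aromatic carbon, with 1H-tetrazol-5-yl in place of carbamoyl on an aromatic carbon. Among the compounds with values here, no measured pair shows the effect of such a change. With only the limit of compound 2 at > 50000 nM to go on, no step beyond the scatter is expected in this assay. The estimated step is a number no higher from compound 2 to compound 3 (the limit leaves the size open). The estimate for compound 3 is 50000 nM, with an expected range from 30000 nM to 100000 nM.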

Compound 3, half-maximal cytotoxic concentration: 1200 nM
Compound 3: middle estimate off by 42-fold (1.62 log units), on the high side; the whole stated range lies above it.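

The aromatic carbon next to the ring nitrogen is not indifferent to what it carries: in this assay, 1H-tetrazol-5-yl in place of carbamoyl gives an at least 41-fold lower number from compound 2 to compound 3 (1.61 log units; beyond the scatter). The earlier compounds shown here, both at the limit, could not show that anything lowers the number. The true size of the step stays open, as its starting point is a limit of the assay and not a number: the limit of > 50000 nM in this assay, at which 2 of the 3 values shown sit.

From the compounds shown here alone, whether other groups on this carbon, such as a nitrile or an amine, stay at the limit or fall as compound 3 does remains open.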